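The source may hold more compounds than are shown below. What is called first, only, known or untested is meant among the compounds shown, and "the series" means these compounds.

Measured so far in a functional assay on a cell-free system (Platelet, plasma, Homo sapiens) for inhibition; a lower number here means a stronger inhibitor, a higher number a weaker inhibitor:
- compound 1 `O=C(Nc1cccc(OCc2ccccc2)c1)C1CCNCC1` gives 229000 nM
- compound 2 `O=C(Nc1cccc(OCc2ccc(-c3ccccc3)cc2)c1)C1CCNCC1` gives 111000 nM
- compound 3 `O=C(Nc1cccc(OCc2ccc(-c3ccc(F)cc3)cc2)c1)C1CCNCC1` gives 35000 nM

Compound 3 holds the lowest number of the three. Its nearest neighbour is compound 2, and the gap is a 3.2-fold lower number from compound 2 to compound 3 (0.50 log units; beyond the scatter). The gap to the simplest member is wider, at a 6.5-fold lower number from compound 1 to compound 3 (0.82 log units; beyond the scatter).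

The next compound is compound 4 `O=C(Nc1cccc(OCc2ccc(-c3ccccc3F)cc2)c1)C1CCNCC1`, an isomer of compound 3 with the same atoms joined differently: 2-fluorophenyl in place of 4-fluorophenyl on an aromatic carbon. Here 2-fluorophenyl stands in place of 4-fluorophenyl on an aromatic carbon, para to a large group.

For the measured compounds named here, two measured steps bear on this. Adding the unsubstituted phenyl gave a 2.1-fold lower number from compound 1 to compound 2 (0.31 log units; beyond the scatter), and adding fluoro gave a 3.2-fold lower number from compound 2 to compound 3 (0.50 log units; beyond the scatter). The second is the closer guide, and it is modest. Going by the values given here, no measured compound shows fluoro anywhere else on that ring, so the size of any shift remains uncertain. Compound 2, without fluoro, marks a plausible upper reference at 111000 nM. A modest step to a higher number is therefore expected in this assay, with part of the fluoro gain lost.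

The expected change is a 1.7-fold higher number from compound 3 to compound 4 (0.23 log units; within the scatter), though a result within the scatter of compound 3 would not surprise.

Compound 4 is estimated at 60000 nM, with an expected range from 25000 nM to 140000 nM.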

Compound 4, half-maximal inhibitory concentration: 62700 nM
The estimate for compound 4 lay 1.0-fold (0.02 log units) below the measured number, within the range that was stated.
By their numbers in this assay, from the lowest: compounds 3, 4 and 2 (each within the scatter of the next, the first and the last beyond it); then compound 1.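

In this assay, 2-fluorophenyl in place of 4-fluorophenyl gives a 1.8-fold higher number from compound 3 to compound 4 (0.25 log units; within the scatter), so this assay does not separate the two fluorophenyl isomers at this position. Against plain phenyl, 2-fluorophenyl gives a 1.8-fold lower number from compound 2 to compound 4 (0.25 log units; within the scatter), so the gain beyond the scatter seen with 4-fluorophenyl is not shown for this isomer, while against hydrogen it gives a 3.7-fold lower number from compound 1 to compound 4 (0.56 log units; beyond the scatter), the only step to compound 4 that clears the scatter. Nothing available here bears on why the two isomers read as they do.

On these data alone, whether chloro, methoxy or a carboxylic acid in place of fluoro on this ring would give a number beyond the scatter of compound 3 remains open. Also open, as far as these compounds go, is whether an amine or a longer chain elsewhere on the shared core would add to the gains seen so far, since every number here is still high in absolute terms, with compound 3 at 35000 nM.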